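Swapping the amide aryl group for cyclopropyl

The compounds below may be only part of what the source reports. "The series", "measured", "known", "first", "only" and "open" are said of these compounds alone.

Measured so far in an assay on isolated protein for inhibition of sterol O-acyltransferase 1 (Mus musculus), tested at 0.1 uM; on this read-out higher numbers stand for more inhibition at the one concentration tested (going by the name of the read-out) and lower numbers for less inhibition:
compound 1 `CCCCCCCCCCCCn1nnc(C(C(=O)Nc2ncccc2C)c2ccccc2)n1` gives 4%
compound 2 `CCCCCCCCCCCCn1nnc(C(C(=O)Nc2c(OC)ncnc2OC)c2ccccc2)n1` gives 39%
compound 3 `CCCCCCCCCCCCn1nnc(C(C(=O)Nc2ccc3c(C)cc(C)nc3n2)c2ccccc2)n1` gives 49%

Compound 2 stands second highest of the three; its nearest neighbour is compound 3, with a number 10 percentage points higher from compound 2 to compound 3 (within the scatter), while compound 1 lies well lower, with a number 35 percentage points higher from compound 1 to compound 2 (beyond the scatter). Compound 4 `CCCCCCCCCCCCn1nnc(C(C(=O)NC2CC2)c2ccccc2)n1` differs from compound 2 by a group of 3 heavy atoms (3 carbon; one three-membered non-aromatic ring of carbon only) in place of a group of 10 heavy atoms (6 carbon, 2 nitrogen, 2 oxygen; one six-membered aromatic ring with 2 hetero atoms), on an amide-type nitrogen. Among the measured compounds shown here, no measured step replaces the aromatic group with a small saturated ring, so the direction is uncertain. The steps of a number 35 percentage points higher from compound 1 to compound 2 (beyond the scatter) and a number 45 percentage points higher from compound 1 to compound 3 (beyond the scatter) show that this position moves the read-out strongly, so a large step in this assay is plausible. Since the small cyclopropyl group carries none of the ring features shared by compounds 2 and 3, compound 4 is expected to fall, with a number 24 percentage points lower from compound 2 to compound 4 (beyond the scatter), to about 15%, estimated between 0% and 45%.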

Compound 4, a percentage reported as inhibition, at one concentration (the size of the read-out at that concentration, not a potency): 10%
Compound 4: the middle estimate sits 5 percentage points above what was measured, within the range that was stated.
By their numbers in this assay, from the lowest: compounds 1 and 4 (each within the scatter of the next); then compounds 2 and 3 (each within the scatter of the next).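

In this assay the change to cyclopropyl on the amide-type nitrogen gives a number 29 percentage points lower from compound 2 to compound 4 (beyond the scatter) and a number 39 percentage points lower from compound 3 to compound 4 (beyond the scatter) as clear drops. Against 3-methylpyridin-2-yl, however, it gives a number 6 percentage points higher from compound 1 to compound 4 (within the scatter) and so no separable change. An aromatic ring on this nitrogen is thus not enough for a high number: compound 1 carries one, compound 4 has none, and their numbers cannot be told apart.

Nothing on hand explains these differences. Going by these compounds, whether cyclohexyl, a larger saturated ring, would stay with compound 4 or approach compound 2 remains open.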